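The source may report more compounds than this note shows. Statements on the series, on what has been measured and on what is new or still open speak of the compounds shown alone.

Working notes on the amide substituent series.

All three measured compounds share the core of compound 1 `Cc1cc(/C=C/C#N)cc(C)c1Oc1cc(Nc2ccc(C#N)cc2)c(N)cc1C(=O)NN` and differ only at the amide-type nitrogen. In a physicochemical assay for solubility, read by HPLC, with a stated time of 4 h, at pH 2 (a lower number here means a less soluble compound, a higher number a more soluble compound), compound 1 gives 89.6 ug/mL. Compound 2 `Cc1cc(/C=C/C#N)cc(C)c1Oc1cc(Nc2ccc(C#N)cc2)c(N)cc1C(=O)NCCCO` carries 3-hydroxypropyl on that nitrogen, and in this assay compound 2 gives 19.9 ug/mL, a step of a 4.5-fold lower number from compound 1 to compound 2 (0.65 log units; beyond the scatter). Compound 3 `Cc1cc(/C=C/C#N)cc(C)c1Oc1cc(Nc2ccc(C#N)cc2)c(N)cc1C(N)=O` carries hydrogen there, and in this assay compound 3 gives 2.09 ug/mL, the lowest of the three numbers; the steps to it are a 43-fold lower number from compound 1 to compound 3 (1.63 log units; beyond the scatter) and a 9.5-fold lower number from compound 2 to compound 3 (0.98 log units; beyond the scatter).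

Compound 4 `Cc1cc(/C=C/C#N)cc(C)c1Oc1cc(Nc2ccc(C#N)cc2)c(N)cc1C(=O)NCCC(F)F` takes the next step: 3,3-difluoropropyl in place of hydrogen on an amide-type nitrogen. Going by the values given here, the step that bears on it most is the one from compound 2 to compound 3, run in reverse, which added a chain of like length; that chain held a hydroxyl, whereas the entering group counts 0 hydrogen-bond donors, 0 hydrogen-bond acceptors, so the same gain is not assumed. A smaller rise in this assay is expected, estimated as a 2.4-fold higher number from compound 3 to compound 4 (0.38 log units; beyond the scatter). Compound 4 is expected to give 5 ug/mL in this assay, within 1.5 ug/mL to 20 ug/mL.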

Compound 4, solubility: 57.6 ug/mL
Compound 4: middle estimate off by 12-fold (1.06 log units), on the low side; measured number above the stated range.
By their numbers in this assay, from the lowest: compound 3; then compound 2; then compounds 4 and 1 (each within the scatter of the next).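

In this assay 3,3-difluoropropyl in place of hydrogen on the amide-type nitrogen gives a 28-fold higher number from compound 3 to compound 4 (1.44 log units; beyond the scatter) with 0 hydrogen-bond donors and 0 hydrogen-bond acceptors in the entering group, so a large rise at this position does not require a hydroxyl on the chain. Difluoromethyl in place of hydroxymethyl on the chain gives a 2.9-fold higher number from compound 2 to compound 4 (0.46 log units; beyond the scatter) and places the chain without a hydroxyl beyond the chain of compound 2. 3,3-difluoropropyl in place of amino gives a 1.6-fold lower number from compound 1 to compound 4 (0.19 log units; within the scatter) and leaves the two compounds level, so a hydrazide-type amino group is not the only substituent that reaches this range.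

No measurement here bears on why these steps fall as they do. As far as these compounds go, how an amine or a carboxylic acid on the chain, or a longer chain, on the amide-type nitrogen would read in this assay stays open.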